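The source may report more compounds than this note shows. Statements on the series, on what has been measured and on what is new or still open speak of the compounds shown alone.

Measured in an assay on isolated protein for inhibition of aldehyde dehydrogenase 1A1 (Homo sapiens), read by spectrophotometry, tested at 10 uM; a higher number here means more inhibition at the concentration tested (going by the name of the read-out), a lower number less inhibition:

- compound 1 `Cc1cccc(Cn2c(CN3CCN(C(=O)c4ccc(C#N)cc4)CC3)nc3ccccc32)c1`: 20.8%
- compound 2 `O=C(C1CC1)N1CCN(Cc2nc3ccccc3n2Cc2ccc(F)cc2)CC1`: 32.7%
- compound 3 `O=C(C1CC1)N1CCN(Cc2nc3ccccc3n2Cc2ccccc2)CC1`: 23.9%

Compound 1 stands lowest of the three numbers. Its nearest neighbour is compound 3, a number within the scatter above it; the furthest is compound 2, which lies beyond the scatter above compound 1. Within the data shown here, the only step measured between two compounds that differ in one place is a number 8.8 percentage points lower from compound 2 to compound 3 (within the scatter), a change on the benzylic aromatic ring, not on the carbonyl side.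

Compound 4 `Cc1cccc(Cn2c(CN3CCN(C(=O)c4ccco4)CC3)nc3ccccc32)c1` carries the change (furan-2-yl in place of 4-cyanophenyl on a carbonyl carbon). Among the measured compounds shown here, no measured step bears on this position: compound 2 and compound 3 carry a different group on that carbonyl carbon and differ from compound 1 in a second place as well, so their values give no single-step reading for the carbonyl substituent. With nothing pointing in either direction, the expected step from compound 1 to compound 4 is a number 1.2 percentage points higher from compound 1 to compound 4 (within the scatter), none beyond the scatter.

Compound 4 is therefore estimated at 22% in this assay, with a range from 8% to 38%.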

Compound 4, a percentage reported as inhibition, at one concentration (the size of the read-out at that concentration, not a potency): 73.2%
Estimate against measurement, compound 4: 51.2 percentage points below; the whole stated range lies below it.
By their numbers in this assay, from the lowest: compounds 1, 3 and 2 (each within the scatter of the next, the first and the last beyond it); then compound 4.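

The carbonyl substituent turns out to be a highly sensitive position in this series: in this assay, furan-2-yl in place of 4-cyanophenyl gives a number 52.4 percentage points higher from compound 1 to compound 4 (beyond the scatter) and lifts compound 4 clear of the other three compounds shown. Among these compounds, the only earlier single-place step, a change from fluoro to hydrogen on an aromatic carbon, gave a number 8.8 percentage points lower from compound 2 to compound 3 (within the scatter) and so gave no sign that any part of these molecules could move the read-out this far. Nothing at hand explains the size of this step.

On these data alone, it remains open whether the gain belongs to the furan-2-yl group itself or to the loss of the 4-cyanophenyl group, which unsubstituted phenyl or thiophen-2-yl on the same carbonyl carbon would help separate. Also open, as far as these compounds go, is whether furan-2-yl gives a similar step on the compounds with a 4-fluorobenzyl group.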